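Working notes: dimethylamino step from compound 3

The source may hold more compounds than are shown below. What is called first, only, known or untested is meant among the compounds shown, and "the series" means these compounds.

In an ADME assay on J774.A1 cells (Mus musculus) for cytotoxicity, read by MTT assay, with a stated time of 48 h (a lower number here means that less compound is tolerated, a higher number that more compound is tolerated), compound 1 (`C/C(=C\c1ccccc1)C(=O)/C=C/c1ccccc1`) gives 34500 nM and compound 2 (`COc1ccc(/C=C/C(=O)/C(C)=C/c2ccccc2)cc1`) gives 51000 nM while compound 3 (`COc1ccc(/C=C(\C)C(=O)/C=C/c2ccccc2)cc1`) gives 54000 nM with all three within the scatter of one another. Compound 4 (`COc1ccc(/C=C(\C)C(=O)/C=C/c2ccc(N(C)C)cc2)cc1`) puts dimethylamino in place of hydrogen on an aromatic carbon. Among the measured compounds shown here, the only measured steps that bear on this change are methoxy in place of hydrogen on an aromatic carbon, namely a 1.5-fold higher number from compound 1 to compound 2 (0.17 log units; within the scatter) and a 1.6-fold higher number from compound 1 to compound 3 (0.19 log units; within the scatter) and neither exceeds the scatter. For the measured compounds named here, no measured compound carries dimethylamino, so these steps guide only loosely. The estimated step is a 1.4-fold lower number from compound 3 to compound 4 (0.15 log units; within the scatter) and no change beyond the scatter is expected. The estimate for compound 4 is 38000 nM with 14000 nM to 90000 nM as the expected range.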

Compound 4, half-maximal cytotoxic concentration: 36200 nM
For compound 4 the middle estimate is 1.0-fold (0.02 log units) above the measured one, and the stated range covers the measured number.
By their numbers in this assay, from the lowest: compounds 1, 4, 2 and 3 (each within the scatter of the next).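

In this assay, dimethylamino in place of hydrogen on an aromatic carbon, para to a large group, gives a 1.5-fold lower number from compound 3 to compound 4 (0.17 log units; within the scatter). The earlier steps shown here covered only methoxy, so this place now also tolerates a nitrogen-bearing group of 3 heavy atoms with no change beyond the scatter, and compound 4 alone holds methoxy and dimethylamino together. No measurement available here gives a reason for this step.

Open, as far as these compounds go, is whether dimethylamino behaves the same on the core of compound 1, without methoxy. Also open, from the compounds shown here alone, is whether a carboxylic acid or a longer chain at this place would stay within the scatter.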